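From allyl to butyl: compound 3 to compound 4

The compounds below may be only part of what the source reports. "The series", "measured", "known", "first", "only" and "open" are said of these compounds alone.

In a functional assay on MCF7 cells (Homo sapiens) for cytotoxicity, read by MTT assay, with a stated time of 24 h (a lower number here means a stronger inhibitor, a higher number a weaker inhibitor), compound 3 `C=CCn1[se]c2ccccc2c1=O` gives 25700 nM. Of the two numbers obtained so far this is the lower one; the nearest is compound 1 `O=C(NC1CCCCC1)c1ccccc1[Se][Se]c1ccccc1C(=O)NC1CCCCC1`, which in this assay gives 90000 nM, a gap that lies beyond the usual scatter. Compound 2 `CC(C)CCNC(=O)c1ccccc1[Se][Se]c1ccccc1C(=O)NCCC(C)C` returns only a limit of the assay in this assay, > 500000 nM, so no number stands for it; the same limit is noted as the limit of > 500000 nM in this assay, at which 1 of the 3 values shown sits.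

Compound 4 `CCCCn1[se]c2ccccc2c1=O` differs from compound 3 in a single place: propyl in place of vinyl on a saturated chain carbon bound to an aromatic nitrogen. Going by the values given here, no pair of measured compounds differs in this way, so nothing among the three measured compounds indicates the size of such a step. The alteration is modest, exchanging an unsaturated chain for a saturated one of similar length at the same position, and no marked change in either direction is expected.

The step expected in this assay is a 1.2-fold higher number from compound 3 to compound 4 (0.07 log units; within the scatter), not beyond the usual scatter. Compound 4 is therefore estimated at 30000 nM in this assay, with a range from 10000 nM to 90000 nM.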

Compound 4, half-maximal inhibitory concentration: 13800 nM
Beside the measured number, compound 4's estimate is 2.2-fold (0.34 log units) above it, within the range that was stated.
By their numbers in this assay, from the lowest: compounds 4 and 3 (each within the scatter of the next); then compound 1. At a limit, above all of these: compound 2.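

Going by these compounds alone, at this position, on a saturated chain carbon bound to an aromatic nitrogen, the allyl to butyl exchange is the only single-place step available, and in this assay it reads a 1.9-fold lower number from compound 3 to compound 4 (0.27 log units; within the scatter). Losing the double bond outside aromatic rings while gaining one chain carbon therefore produces no step beyond the scatter, and the two compounds cannot be told apart in this read-out. No measured property among the data shown bears on this result.

From the compounds shown here alone, whether a longer chain, a benzyl group, or a chain ending in an amine or a carboxylic acid at this position would give a step beyond the scatter remains open. The exchange alters saturation and chain length together, and the contribution of each remains unresolved.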